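A few compounds are considered here, and "the series" means these few. Any claim that something is new, unique, unknown or untested is made for them only; others in the source may bear on it.

Measured compounds in a functional assay on cells (Cancer cell lines, Homo sapiens) for cytotoxicity, read by sulforhodamine B assay, with a stated time of 48 h; a higher number here means a weaker inhibitor of growth, a lower number a stronger inhibitor of growth:
Compound 1 `COc1ccc(C2CC(c3ccccc3)=NN2C2=NC(=O)/C(=C3\C(=O)Nc4ccccc43)S2)cc1` gives 2020 nM.
Compound 2 `COc1ccc(C2CC(c3ccc4ccccc4c3)=NN2C2=NC(=O)/C(=C3\C(=O)Nc4ccccc43)S2)cc1` gives 5960 nM.
Compound 3 `O=C1N=C(N2N=C(c3ccccc3)CC2c2ccc(Cl)cc2)S/C1=C1/C(=O)Nc2ccccc21` gives 320 nM.

Compound 3 gives the lowest number of the three, that is, it is the strongest inhibitor of growth here; its nearest neighbour is compound 1, and the gap between them is beyond the scatter, as is the larger gap to compound 2. Compound 4 `O=C1N=C(N2N=C(c3ccc4ccccc4c3)CC2c2ccc(Cl)cc2)S/C1=C1/C(=O)Nc2ccccc21` is not yet measured. It differs from compound 3 in one place: naphthalen-2-yl in place of phenyl on a carbon with a double bond to nitrogen.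

Among the compounds with values here, one measured step bears on this change directly. The same swap, made on the core that carries a methoxy group, is seen in a 3.0-fold higher number from compound 1 to compound 2 (0.47 log units; beyond the scatter), a weakening of growth inhibition that lies beyond the scatter. Whether the chloro group in compound 3 alters the size of that effect cannot be told from these three compounds, so the same step is the best guide. A modest weakening is therefore expected, a 3.0-fold higher number from compound 3 to compound 4 (0.47 log units; beyond the scatter). Compound 4 is thus estimated to give 950 nM in this assay, within a range of 400 nM to 2500 nM.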

Compound 4, concentration for 50% growth inhibition: 740 nM
For compound 4 the middle estimate is 1.3-fold (0.11 log units) above the measured one; low and high end bracket the measured number.
By their numbers in this assay, from the lowest: compound 3; then compound 4; then compound 1; then compound 2.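

Phenyl to naphthalen-2-yl on the carbon with a double bond to nitrogen also weakens growth inhibition on the chloro-bearing core, seen in a 2.3-fold higher number from compound 3 to compound 4 (0.36 log units; beyond the scatter) in this assay, so this change now rests on two pairs rather than one. Its size carries over between the two cores: the same change on two cores in this assay, a 3.0-fold higher number (0.47 log units; beyond the scatter) from compound 1 to compound 2 and a 2.3-fold higher number (0.36 log units; beyond the scatter) from compound 3 to compound 4, 1.3-fold (0.11 log units) apart, within the scatter of two such steps. Chloro in place of methoxy also lowers the number when naphthalen-2-yl is present, seen in an 8.1-fold lower number from compound 2 to compound 4 (0.91 log units; beyond the scatter), and that change likewise keeps its size: the same change on two cores in this assay, a 6.3-fold lower number (0.80 log units; beyond the scatter) from compound 1 to compound 3 and an 8.1-fold lower number (0.91 log units; beyond the scatter) from compound 2 to compound 4, 1.3-fold (0.11 log units) apart, within the scatter of two such steps.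

The compounds shown leave open how this carbon would respond to a group outside the two aromatic ones here, such as a methyl group, a longer alkyl chain or a ring bearing an amine. On these data alone, whether fluoro or nitrile would match chloro in place of methoxy also remains unknown.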